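Fluoro for Isopropyl on a Scaffold Without Measured Potency

The source may hold more compounds than are shown below. What is called first, only, known or untested is meant among the compounds shown, and "the series" means these compounds.

Measured so far:
compound 1 `Cc1cnc(Nc2ccc(C(C)C)cc2)nc1Nc1nc2ccccc2s1` — > 50000 nM
compound 2 `CS(=O)(=O)c1ccc(Nc2ncc(F)c(Nc3nc4ccc(Cl)cc4s3)n2)cc1` — > 50000 nM

The read-out here is a functional assay on MCF7 cells (Homo sapiens) for antiproliferative activity, read by MTT assay, with a stated time of 48 h; on this read-out higher numbers stand for weaker inhibition and lower numbers for stronger inhibition. In this assay compound 1 gives > 50000 nM, which is a limit of the assay rather than a measured number. Compound 2, a more distant relative with different substituents on both aryl groups, also returns only a limit in this assay, namely > 50000 nM. Both results thus sit at the same ceiling: the limit of > 50000 nM in this assay, at which 2 of the 2 values shown sit. Among the compounds with values here, no step between measured compounds can therefore be read, and where compound 1 stands within the active range is unknown; it is simply not measurably active under these conditions.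

Compound 3 `Cc1cnc(Nc2ccc(F)cc2)nc1Nc1nc2ccccc2s1` is the single-point variant of compound 1 with fluoro in place of isopropyl on an aromatic carbon. Within the data shown here, with no measured step to lean on, the only reasonable expectation is that compound 3 stays at the limit as well, and the step from compound 1 to compound 3 is expected to be a number no higher from compound 1 to compound 3 (the limit leaves the size open), no change beyond scatter. Compound 3 is thus estimated at 50000 nM, with a range from 15000 nM to 150000 nM.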

Compound 3, half-maximal inhibitory concentration: > 50000 nM
Compound 3: a limit, no number; the forecaster's own chance of this, stated with the estimate: 75%; the middle value lies on the limit itself.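

In this assay compound 3 gives > 50000 nM as a limit of the assay and not a number. Within the data shown here, no step from compound 1 to compound 3 can be read, and all three compounds share one result: the limit of > 50000 nM in this assay, at which 3 of the 3 values shown sit. The compounds shown leave open how isopropyl and fluoro compare, and whether any compound with this core reaches a measurable value.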